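A Single Methyl on the Aryl Ring of Compound 2

The source may report more compounds than this note shows. Statements on the series, on what has been measured and on what is new or still open speak of the compounds shown alone.

Compound 2 `CC1=NN(c2ccccc2)C(=O)C12C=CC(=O)C=C2c1ccccc1` gives 17800 nM in a functional assay on HCT-116 cells (Homo sapiens) for antiproliferative activity, read by CCK-8 assay, with a stated time of 72 h (on this read-out lower numbers stand for stronger inhibition and higher numbers for weaker inhibition), the highest of the two numbers measured here. Compound 1 `CC1=NN(c2ccc(C)cc2)C(=O)C12C=CC(=O)C=C2c1cccc(C)c1` gives 8340 nM. Compound 3 `CC1=NN(c2ccc(Cl)cc2)C(=O)C12C=CC(=O)C=C2c1ccccc1` shows only a limit, > 100000 nM (the limit of > 100000 nM in this assay, at which 1 of the 3 values shown sits). Going by the values given here, the only measured step away from compound 2 is an at least 5.6-fold higher number from compound 2 to compound 3 (0.74 log units; beyond the scatter). Compound 4 `CC1=NN(c2ccccc2)C(=O)C12C=CC(=O)C=C2c1cccc(C)c1` differs from compound 2 by methyl in place of hydrogen on an aromatic carbon. Among the compounds with values here, no measured step covers this exact change; compound 1, which carries this methyl together with a second one, gives 8340 nM against compound 2 at 17800 nM, so a modest drop is expected. Compound 4 is therefore estimated at 12000 nM, within 5000 nM to 30000 nM, a step of a 1.5-fold lower number from compound 2 to compound 4 (0.17 log units; within the scatter).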

Compound 4, half-maximal inhibitory concentration: > 100000 nM
Compound 4: no number, only a limit; the forecaster's own chance of this, stated with the estimate: 5%; at least 8.3-fold (0.92 log units) between middle value and limit.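

Changing phenyl to 3-methylphenyl on its own gives an at least 5.6-fold higher number from compound 2 to compound 4 (0.74 log units; beyond the scatter), so this methyl brings no gain by itself. Removing the second methyl of compound 1 gives an at least 11-fold higher number from compound 1 to compound 4 (1.07 log units; beyond the scatter), so the activity of compound 1 depends on that second methyl as well. Compound 4 has only a limit, not a number: the limit of > 100000 nM in this assay, at which 2 of the 4 values shown sit.

As far as these compounds go, how far compound 4 lies past this limit remains unknown. Also open, from the compounds shown here alone, is whether an amine or a methoxy group on this same aromatic carbon would behave as the methyl does.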